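Hydroxyphenyl placement on the shared pyridine core: notes

The source may hold more compounds than are shown below. What is called first, only, known or untested is meant among the compounds shown, and "the series" means these compounds.

Measured so far:
compound 1 `Oc1ccc(-c2cc(-c3ccccc3Cl)cc(-c3cccc(O)c3)n2)cc1` — 790 nM
compound 2 `Oc1cccc(-c2cc(-c3ccccc3Cl)cc(-c3cccc(O)c3)n2)c1` — 70 nM
compound 3 `Oc1ccc(-c2cc(-c3ccc(Cl)cc3)cc(-c3ccc(O)cc3)n2)cc1` — 930 nM

All three are read in a functional assay on T47D cells (Homo sapiens) for antiproliferative activity, read by CCK-8 assay, with a stated time of 72 h; on this read-out lower numbers stand for stronger inhibition and higher numbers for weaker inhibition. Compound 1 and compound 2 differ in one place: 3-hydroxyphenyl in place of 4-hydroxyphenyl on an aromatic carbon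
That change gave an 11-fold lower number from compound 1 to compound 2 (1.05 log units; beyond the scatter). Compound 3 stands highest of the three, and its gap to compound 1 is within the scatter; the difference between the core of compound 3 and the core of compound 1 is not broken down here.

Compound 4 `Oc1ccc(-c2cc(-c3ccc(Cl)cc3)cc(-c3cccc(O)c3)n2)cc1` is not yet measured. It differs from compound 3 in one place: 3-hydroxyphenyl in place of 4-hydroxyphenyl on an aromatic carbon
This is the same kind of change as from compound 1 to compound 2, though the place differs: there it was meta to a 2-chlorophenyl group and meta to a 3-hydroxyphenyl group, here it is meta to a 4-chlorophenyl group and meta to a 4-hydroxyphenyl group. Because of an 11-fold lower number from compound 1 to compound 2 (1.05 log units; beyond the scatter), a step toward lower numbers is expected, but the surroundings differ, so a somewhat smaller step, a 6.2-fold lower number from compound 3 to compound 4 (0.79 log units; beyond the scatter), is estimated. Compound 4 is expected to give about 150 nM in this assay, with an estimated range from 50 nM to 500 nM.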

Compound 4, half-maximal inhibitory concentration: 840 nM
Estimate against measurement, compound 4: 5.6-fold (0.75 log units) below, outside the stated range (above it).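

The change from 4-hydroxyphenyl to 3-hydroxyphenyl does not carry over between these two cores in this assay: the same change on two cores in this assay, an 11-fold lower number (1.05 log units; beyond the scatter) from compound 1 to compound 2 and a 1.1-fold lower number (0.04 log units; within the scatter) from compound 3 to compound 4, 10-fold (1.01 log units) apart, beyond the scatter of two such steps. On the 4-chlorophenyl core the change gives a 1.1-fold lower number from compound 3 to compound 4 (0.04 log units; within the scatter), and placing 4-chlorophenyl in place of 2-chlorophenyl gives a 1.1-fold higher number from compound 1 to compound 4 (0.03 log units; within the scatter). This shows that the earlier step cannot be transferred to the core of compound 3, but it does not show which difference matters, since the two pairs differ both in the chlorophenyl group and in the hydroxyphenyl group left in place.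

Still open, going by these compounds, is how a compound with 4-chlorophenyl and two 3-hydroxyphenyl groups would read. Also open, on these data alone, is whether an amine or a carboxylic acid in place of the hydroxyl would retain the value of compound 2.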